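The source may report more compounds than this note shows. Statements on the series, on what has been measured and on what is new or still open speak of the compounds shown alone.

Measured compounds:
- Compound 1 `COc1ccccc1/C=C/C(=O)/C=C/c1ccc(OCc2cn(CCOc3cc(=O)oc4ccccc34)nn2)c(OC)c1`, 70%
- Compound 2 `COc1cc(/C=C/C(=O)/C=C/c2cc(OC)c(OC)c(OC)c2)ccc1OCc1cn(CCOc2cc(=O)oc3ccccc23)nn1`, 89%
- Compound 3 `COc1cc(/C=C/C(=O)/C=C/c2cc(OC)c(OC)c(OC)c2)ccc1OCc1cn(CCCCCOc2cc(=O)oc3ccccc23)nn1`, 53%

The three compounds were tested in a functional assay on HCT-116 cells (Homo sapiens) for inhibition, read by sulforhodamine B assay, with a stated time of 48 h, tested at 50 uM; on this read-out lower numbers stand for less inhibition of growth and higher numbers for more inhibition of growth at the one concentration tested. Compound 3 gives the lowest of the three numbers; compound 1 stands nearest to it, and compound 2 furthest, both beyond the scatter.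

Compound 4 `COc1cc(/C=C/C(=O)/C=C/c2cccc3ccccc23)ccc1OCc1cn(CCCCCOc2cc(=O)oc3ccccc23)nn1` has not been measured. It differs from compound 3 in one place: naphthalen-1-yl in place of 3,4,5-trimethoxyphenyl on a double-bonded chain carbon bound to a double-bonded chain carbon.

Going by the values given here, only one measured step touches the same position. The change from 2-methoxyphenyl to 3,4,5-trimethoxyphenyl gave a number 19 percentage points higher from compound 1 to compound 2 (beyond the scatter), a modest gain. Among the compounds with values here, no measured pair shows what happens when the 3,4,5-trimethoxyphenyl itself is replaced, so the direction for compound 4 is uncertain. Since the 3,4,5-trimethoxyphenyl in compound 2 was the better of the two groups compared, its removal in favour of naphthalen-1-yl is expected to give a small loss or a change within the scatter, so the step of a number 5 percentage points lower from compound 3 to compound 4 (within the scatter) is estimated as slightly downward. Compound 4 is therefore expected to give about 48% in this assay, with a range from 28% to 68%.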

Compound 4, percent growth inhibition at one concentration: 42%
Compound 4: the middle estimate sits 6 percentage points above what was measured; measured number inside the range.
By their numbers in this assay, from the lowest: compound 4; then compound 3; then compound 1; then compound 2.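

In this assay, going by these compounds alone, the exchange of 3,4,5-trimethoxyphenyl for naphthalen-1-yl on a double-bonded chain carbon bound to a double-bonded chain carbon gives a number 11 percentage points lower from compound 3 to compound 4 (beyond the scatter) and so shows for the first time what happens when the 3,4,5-trimethoxyphenyl itself is replaced at this position. Together with a number 19 percentage points higher from compound 1 to compound 2 (beyond the scatter) as the earlier step, this puts the 3,4,5-trimethoxyphenyl on the side of the higher number in both pairs, and no listed pair goes against this, although the two pairs carry different chains elsewhere in the shared core. The change brings 2 six-membered aromatic rings of carbon only and 0 hydrogen-bond acceptors in place of one such ring and 3 hydrogen-bond acceptors, and nothing given here ties the lower number to either difference.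

The compounds shown leave open whether a naphthalen-2-yl, a pyridine ring or a phenyl ring carrying a single 4-methoxy group or an amine would stand nearer to the 3,4,5-trimethoxyphenyl or to the naphthalen-1-yl at this place. They also leave open whether the naphthalen-1-yl exchange would have a step of similar size on the chain that compound 2 carries.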